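A few compounds are considered here, and "the series" means these few. Any claim that something is new, unique, unknown or untested is made for them only; others in the source may bear on it.

Working notes on the stilbene series.

Of the compounds shown here, three have been measured in an assay on HepG2 cells for activation of nuclear factor erythroid 2-related factor 2 (Homo sapiens), read by a luciferase reporter, with a stated time of 5 h; on this read-out higher numbers stand for an effect only at larger amounts of compound and lower numbers for an effect already at smaller amounts. Compound 1 `COc1cccc(/C=C/c2cccc(F)c2)c1OC` gives 1900 nM. Compound 2 `Fc1ccccc1/C=C/c1ccc(Cl)cc1` gives 1600 nM. Going by the values given here, compound 3 `COc1cccc(/C=C/c2ccccc2)c1OC` gives 4700 nM, the highest number of the three; the nearest is compound 1, and the only single-point step measured so far, a 2.5-fold higher number from compound 1 to compound 3 (0.39 log units; beyond the scatter), runs between them. Compound 2 sits lower still than compound 3, but the two differ in more than one place, so that gap is not read as a step.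

The next compound, compound 4 `COc1cccc(/C=C/c2ccc(C(C)C)cc2)c1OC`, differs from compound 3 by one change: isopropyl in place of hydrogen on an aromatic carbon. Among the compounds with values here, no measured step bears directly on an isopropyl group or on this position. Within the data shown here, the one step available, from compound 1 to compound 3, shows that taking a small substituent off the unsubstituted ring raised the number by a modest, beyond-scatter amount; compound 4 goes the other way, putting a substituent onto that ring. On that indirect basis a modest lowering of the number in this assay is expected, a 1.9-fold lower number from compound 3 to compound 4 (0.27 log units; within the scatter), with wide uncertainty since the group and the place are both new to the series. The estimate for compound 4 is 2500 nM, within 900 nM to 7000 nM.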

Compound 4, half-maximal effective concentration: 2700 nM
Estimate against measurement, compound 4: 1.1-fold (0.03 log units) below; measured number inside the range.
By their numbers in this assay, from the lowest: compounds 2, 1, 4 and 3 (each within the scatter of the next, the first and the last beyond it).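

In this assay, isopropyl in place of hydrogen on an aromatic carbon, para to a large group, gives a 1.7-fold lower number from compound 3 to compound 4 (0.24 log units; within the scatter), so at this position a group of 3 heavy atoms (3 carbon) leaves the number within the scatter of the unsubstituted compound. Going by these compounds alone, the only earlier single-point step, a 2.5-fold higher number from compound 1 to compound 3 (0.39 log units; beyond the scatter), lies beyond the scatter, but it concerns fluoro and says nothing about a branched carbon group or about this position, so the two steps cannot be combined into a trend for substituents on this ring. No independent measurement accompanies this result to explain it.

The compounds shown leave open whether an amine, a carboxylic acid or a longer chain in the same place would also stay within the scatter of compound 3, or would produce a step beyond it. From the compounds shown here alone, it also remains open whether isopropyl would give a comparable step on a different core, such as that of compound 2, or at another position on this ring.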